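Acetyl in place of ethyl: what to expect

A few compounds are considered here, and "the series" means these few. Any claim that something is new, unique, unknown or untested is made for them only; others in the source may bear on it.

Of the compounds shown here, three sharing one core have been measured in a physicochemical assay for solubility, at pH 7.4; on this read-out higher numbers stand for higher solubility and lower numbers for lower solubility. Compound 1 `Cc1cc(NC(=O)Nc2ccc(C(C)(C)C)cc2)c2ccccc2n1` gives 6200 nM, compound 2 `CSc1ccc(NC(=O)Nc2cc(C)nc3ccccc23)cc1` gives 1300 nM, and compound 3 `CCc1ccc(NC(=O)Nc2cc(C)nc3ccccc23)cc1` gives 3300 nM. Two steps fix where compound 3 stands: a 1.9-fold lower number from compound 1 to compound 3 (0.27 log units; within the scatter), and a 2.5-fold higher number from compound 2 to compound 3 (0.40 log units; beyond the scatter).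

Compound 4 `CC(=O)c1ccc(NC(=O)Nc2cc(C)nc3ccccc23)cc1` has acetyl in place of ethyl on an aromatic carbon, para to a large group: acetyl in place of ethyl on an aromatic carbon. Going by the values given here, the three measured steps all exchange one group for another at this same place, so they are the only guide. The largest of them is modest, a 4.8-fold lower number from compound 1 to compound 2 (0.68 log units; beyond the scatter). None of them brings in acetyl, and the data do not show which way this group moves the number. A step beyond the scatter is therefore not expected in this assay, and neither direction is favoured with any confidence. The expected change is a 1.1-fold lower number from compound 3 to compound 4 (0.04 log units; within the scatter). For compound 4 the estimated value is 3000 nM, with an expected range of 1100 nM to 8000 nM.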

Compound 4, solubility: 3800 nM
For compound 4 the middle estimate is 1.3-fold (0.10 log units) below the measured one; low and high end bracket the measured number.
By their numbers in this assay, from the lowest: compound 2; then compounds 3, 4 and 1 (each within the scatter of the next).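

In this assay, going by these compounds alone, acetyl, the first group here with a carbonyl and a hydrogen-bond acceptor, gives a 1.2-fold higher number from compound 3 to compound 4 (0.06 log units; within the scatter) and so does not separate from ethyl at this position on the aromatic ring. The exchange for tert-butyl reads the same way, with a 1.6-fold lower number from compound 1 to compound 4 (0.21 log units; within the scatter) as its step, and only the exchange for methylsulfanyl passes the scatter, with a 2.9-fold higher number from compound 2 to compound 4 (0.47 log units; beyond the scatter) as its step. Compound 2 therefore stays alone at the low end of the series, while ethyl, acetyl and tert-butyl lie within the scatter of one another.

As far as these compounds go, how an amine, a carboxylic acid or a simple amide would read at this place in this assay stays open. Nothing given here offers a measured reason for any of these numbers.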